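A few compounds are considered here, and "the series" means these few. Any claim that something is new, unique, unknown or untested is made for them only; others in the source may bear on it.

For the measured compounds named here, in a functional assay on PC-3 cells (Homo sapiens) for inhibition, read by MTT assay, with a stated time of 72 h (on this read-out higher numbers stand for weaker inhibition and lower numbers for stronger inhibition), compound 3 (`FC(F)(F)c1ccc(CSc2nc(Sc3nncs3)cc(C(F)(F)F)n2)cc1`) gives 7880 nM and sits within the scatter of compound 1 (`Cc1csc(Sc2cc(C(F)(F)F)nc(SCc3ccc(C(F)(F)F)cc3)n2)n1`) at 12000 nM but clear of compound 2 (`FC(F)(F)c1ccc(CSc2nc(Sc3ccccn3)cc(C(F)(F)F)n2)cc1`) at 25200 nM on the numbers so far. Going by the values given here, compound 4 (`Cc1nnc(Sc2cc(C(F)(F)F)nc(SCc3ccc(C(F)(F)F)cc3)n2)s1`) departs from compound 3 by methyl in place of hydrogen on an aromatic carbon as its single change: methyl in place of hydrogen on an aromatic carbon. Among the compounds with values here, no measured pair tests this methyl alone. The nearest steps are swaps on the same sulfur: a 1.5-fold lower number from compound 1 to compound 3 (0.18 log units; within the scatter) stays within the scatter, while a 2.1-fold higher number from compound 1 to compound 2 (0.32 log units; beyond the scatter) and a 3.2-fold lower number from compound 2 to compound 3 (0.50 log units; beyond the scatter) are modest and both involve pyridin-2-yl. No step beyond the scatter is therefore expected in this assay for this methyl. The estimated step is a 1.1-fold higher number from compound 3 to compound 4 (0.06 log units; within the scatter) on this reasoning. Compound 4 is estimated at 9000 nM with 4000 nM to 20000 nM as the expected range.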

Compound 4, half-maximal inhibitory concentration: > 50000 nM
Compound 4: a limit, no number (the forecaster's own chance of this, stated with the estimate: 3%); middle value at least 5.5-fold (0.74 log units) from the limit.
By their numbers in this assay, from the lowest: compounds 3 and 1 (each within the scatter of the next); then compound 2. At a limit, above all of these: compound 4.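

In this assay, methyl in place of hydrogen on this aromatic carbon carries a single added carbon, yet it gives an at least 6.3-fold higher number from compound 3 to compound 4 (0.80 log units; beyond the scatter). Set against the other sulfur substituents, the floors read an at least 4.1-fold higher number from compound 1 to compound 4 (0.61 log units; beyond the scatter) and an at least 1.9-fold higher number from compound 2 to compound 4 (0.29 log units; that floor lies within the scatter), so only the separation from compound 1 is secure. Compound 4 stands at a limit of the assay, not at a number: the limit of > 50000 nM in this assay, at which 1 of the 4 values shown sits.

From the compounds shown here alone, how far past that limit compound 4 lies stays open. Also open, going by these compounds, is whether an ethyl, a chlorine or an amine on the same carbon would behave like methyl or like hydrogen.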